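From an unmeasured isopropyl compound to a methoxy one

The source may report more compounds than this note shows. Statements on the series, on what has been measured and on what is new or still open speak of the compounds shown alone.

- compound 1 `CCc1ccc(Nc2nc(Nc3ccc(N4CCN(C)CC4)cn3)ncc2Cl)cc1`: 12100 nM
- compound 2 `CC(C)c1ccccc1Nc1nc(Nc2ccc(N3CCN(C)CC3)cn2)ncc1Cl`: "not determined" (no result reported)

In an ADME assay on L02 cells (Homo sapiens) for inhibition, read by CCK-8 assay, with a stated time of 48 h (a higher number here means a weaker inhibitor of growth, a lower number a stronger inhibitor of growth), compound 2 has no number to stand on, being recorded as "not determined" (no result reported). The only figure available comes from compound 1, which gives 12100 nM. Still awaiting measurement is compound 3 `COc1ccc(Nc2nc(Nc3ccc(N4CCN(C)CC4)cn3)ncc2Cl)cc1`. The change 4-methoxyphenyl in place of 2-isopropylphenyl on a nitrogen on an aromatic ring puts 4-methoxyphenyl in place of 2-isopropylphenyl on a nitrogen on an aromatic ring. Among the measured compounds shown here, no measured step shows what such a change does in this assay. The expectation is therefore a result within the scatter of compound 1 at 12100 nM, with no direction favoured, though this rests on a single number. For compound 3 the estimated value is 12000 nM, with an expected range from 5000 nM to 30000 nM.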

Compound 3, concentration for 50% growth inhibition: 3150 nM
For compound 3 the middle estimate is 3.8-fold (0.58 log units) above the measured one, outside the stated range (below it).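

In this assay, a 3.8-fold lower number from compound 1 to compound 3 (0.58 log units; beyond the scatter) shows that the group on this aromatic carbon matters: with methoxy in place of ethyl, the difference lies beyond the scatter, in the direction of a stronger inhibitor of growth, though the step is modest and rests on one pair. The change from 2-isopropylphenyl to 4-methoxyphenyl cannot be read, as compound 2 has no number to compare. No measurement at hand bears on what lies behind the step from ethyl to methoxy.

Going by these compounds, whether an amine, a hydroxyl or a longer chain such as ethoxy on the same aromatic carbon would extend this step or reverse it remains open. So does whether methoxy in place of ethyl would give a similar step on a different core.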